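Swapping fluoro for chloro on the amide-bearing ring

This account rests on a few compounds, and the source may have more. Where it says the series, first, only, none or still open, it means among the compounds named here.

Measured compounds:
- compound 1, `CCCS(=O)(=O)Nc1ccc(Cl)c(C(=O)Nc2cnc3[nH]nc(OC)c3c2)c1F`: 1080000 ng.h/mL
- compound 2, `CCCS(=O)(=O)Nc1ccc(F)c(C(=O)Nc2cnc3[nH]ncc3c2)c1F`: 40000 ng.h/mL

Of the compounds shown here, two have been measured in an ADME assay on the whole organism (plasma, strain CD-1) for pharmacokinetics, with Mus musculus as the target, at a dose of 30 mg/kg by the oral route; on this read-out higher numbers stand for higher exposure at the dose given and lower numbers for lower exposure. In this assay compound 1 reaches 1080000 ng.h/mL, while compound 2 gives 40000 ng.h/mL. Compound 2 thus stands at the lower of the two numbers, and the gap up to compound 1 is well beyond the usual scatter. Going by the values given here, compound 1 and compound 2 differ in more than one place, so the two values show only that the pair sits far apart, not which change carries the gap.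

Compound 3, `CCCS(=O)(=O)Nc1ccc(Cl)c(C(=O)Nc2cnc3[nH]ncc3c2)c1F`, has not yet been measured. It is built from compound 2 by one change: chloro in place of fluoro on an aromatic carbon. Compound 3 therefore shares the chloro of compound 1 but keeps the unsubstituted core of compound 2. Among the compounds with values here, no single-change step between measured compounds is available to size this move, so the expectation rests on compound 3 lying somewhere between the two known values. A rise from compound 2 is expected, of size a 3.0-fold higher number from compound 2 to compound 3 (0.48 log units; beyond the scatter). For compound 3 the estimated exposure is 120000 ng.h/mL, with a range from 30000 ng.h/mL to 500000 ng.h/mL.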

Compound 3, area under the concentration-time curve: 147000 ng.h/mL
Beside the measured number, compound 3's estimate is 1.2-fold (0.09 log units) below it; the range from low to high includes it.
By their numbers in this assay, from the lowest: compound 2; then compound 3; then compound 1.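

On the core of compound 2, chloro in place of fluoro on the aromatic carbon para to the (propylsulfonyl)amino group gives a 3.7-fold higher number from compound 2 to compound 3 (0.57 log units; beyond the scatter) in this assay, so exchanging one halogen at this position is enough to shift exposure beyond the scatter. The other half of the comparison is hydrogen in place of methoxy on an aromatic carbon, which gives a 7.3-fold lower number from compound 1 to compound 3 (0.87 log units; beyond the scatter) in this assay, so the loss of methoxy also matters once chloro is held fixed. The wide gap between compound 1 and compound 2 therefore resolves into two separate steps, and neither change alone accounts for all of it. Nothing shown here explains why either step has the effect it does.

Going by these compounds, it remains open whether the swap from fluoro to chloro would have the same size on the methoxy-bearing core of compound 1, since the step is read only on the core without methoxy. Also open, on these data alone, is how a bromo or a methyl at the same carbon, or an ethoxy in place of the methoxy, would compare.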